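A few compounds are considered here, and "the series" means these few. Any claim that something is new, unique, unknown or untested is made for them only; others in the source may bear on it.

Compound 1 `COc1ccc(-c2c(S(=O)(=O)c3cc(F)cc(F)c3)cnc3c(F)cccc23)cc1` and compound 2 `O=S(=O)(c1cc(F)cc(F)c1)c1cnc2c(F)cccc2c1-c1ccc(Cl)cc1` have each been measured in an ADME assay on microsomes from liver (Homo sapiens) for metabolic stability, tested at 2.5 uM; on this read-out lower numbers stand for slow clearance and higher numbers for fast clearance. In that assay compound 1 gives 2.59 mL/min, and compound 2 gives 0.73 mL/min. Among the two numbers in hand, compound 1 stands highest; its only neighbour is compound 2, separated by a 3.5-fold lower number from compound 1 to compound 2 (0.55 log units; beyond the scatter), a modest step that lies beyond the scatter.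

Compound 3 `COc1ccc(-c2c(S(=O)(=O)c3ccc(F)c(F)c3)cnc3c(F)cccc23)cc1` has not yet been run in this assay. It differs from compound 1 in a single place:

3,4-difluorophenyl in place of 3,5-difluorophenyl on a sulfonyl sulfur

Going by the values given here, the one measured step, from compound 1 to compound 2, concerns a chloro in place of a methoxy on an aromatic carbon and so does not bear on a 3,4-difluorophenyl in place of a 3,5-difluorophenyl on a sulfonyl sulfur. Among the compounds with values here, no measured pair speaks to this change. With nothing to point either way, the estimated step of a 1.0-fold higher number from compound 1 to compound 3 (0.00 log units; within the scatter) is expected to stay within the scatter. Compound 3 is therefore expected to give about 2.6 mL/min in this assay, with a range from 1.3 mL/min to 5.2 mL/min.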

Compound 3, intrinsic clearance in a liver preparation (reported as CLH), per the amount of preparation that the assay uses: 2.12 mL/min
Beside the measured number, compound 3's estimate is 1.2-fold (0.09 log units) above it; measured number inside the range.
By their numbers in this assay, from the lowest: compound 2; then compounds 3 and 1 (each within the scatter of the next).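

In this assay, exchanging 3,5-difluorophenyl for 3,4-difluorophenyl on the sulfonyl sulfur gives a 1.2-fold lower number from compound 1 to compound 3 (0.09 log units; within the scatter), so this rearrangement of the same atoms does not separate the two compounds on this read-out. The earlier pair spoke only to a chloro in place of a methoxy on an aromatic carbon, a change that gave a 3.5-fold lower number from compound 1 to compound 2 (0.55 log units; beyond the scatter), and it said nothing about the group on the sulfonyl sulfur. Here, at least for these two difluorophenyl groups, that group can be rearranged without a step beyond the scatter, and no measurement shown here offers an explanation for that result.

The compounds shown leave open whether the number would hold with something other than a difluorophenyl on the sulfonyl sulfur, such as an unsubstituted phenyl, a pyridine or a simple methyl. They also leave open whether 3,4-difluorophenyl in place of 3,5-difluorophenyl would be just as small a step in the chloro series of compound 2, whose number is the lowest of the three and beyond the scatter of compound 1.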